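The source may report more compounds than this note shows. Statements on the series, on what has been measured and on what is new or still open speak of the compounds shown alone.

The account follows a small series built on one shared core and tested in an ADME assay on HUVEC cells (Homo sapiens) for antiproliferative activity, read by MTT assay, with a stated time of 48 h; on this read-out lower numbers stand for stronger inhibition and higher numbers for weaker inhibition. Compound 1 `N#CC1=C(N)Oc2c(N)cc3nc4ccccc4nc3c2C12C(=O)N(Cc1cnnn1-c1ccccc1Cl)c1ccccc12` carries a 2-chlorophenyl group on an aromatic nitrogen. In this assay compound 1 gives > 50000 nM, which is a limit of the assay and not a number. Compound 2 `Cc1ccc(-n2nncc2CN2C(=O)C3(C(C#N)=C(N)Oc4c(N)cc5nc6ccccc6nc5c43)c3ccccc32)cc1Cl` carries a 3-chloro-4-methylphenyl group in that place. In this assay compound 2 gives > 50000 nM, again a limit. Compound 3 `Cc1ccc(Cl)cc1-n1nncc1CN1C(=O)C2(C(C#N)=C(N)Oc3c(N)cc4nc5ccccc5nc4c32)c2ccccc21` carries a 5-chloro-2-methylphenyl group in that place. In this assay compound 3 gives > 50000 nM, also a limit. Compound 3 thus stands together with the other two at the limit of > 50000 nM in this assay, at which 3 of the 3 values shown sit. The steps that lead to it, a step that the two limits leave unreadable from compound 1 to compound 3 and a step that the two limits leave unreadable from compound 2 to compound 3, cannot be sized, and the same holds for a step that the two limits leave unreadable from compound 1 to compound 2. Compound 4 `N#CC1=C(N)Oc2c(N)cc3nc4ccccc4nc3c2C12C(=O)N(Cc1cnnn1-c1c(Cl)cc(Cl)cc1Cl)c1ccccc12` is the next member. It differs from compound 3 in one place: 2,4,6-trichlorophenyl in place of 5-chloro-2-methylphenyl on an aromatic nitrogen. Going by the values given here, no measured step gives a size for a change of this kind, and every compound measured so far sits at the limit. The expected step from compound 3 to compound 4, a step that the limit leaves unreadable from compound 3 to compound 4, is therefore none beyond the scatter, with compound 4 expected to remain at the limit. For compound 4 the estimate in this assay is 100000 nM, in a range from 30000 nM to 400000 nM.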

Compound 4, half-maximal inhibitory concentration: 18300 nM
Beside the measured number, compound 4's estimate is 5.5-fold (0.74 log units) above it, outside the stated range (below it).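

In this assay, going by these compounds alone, the 2,4,6-trichlorophenyl group gives the first readable steps at this position: an at least 2.7-fold lower number from compound 3 to compound 4 (0.43 log units; beyond the scatter), an at least 2.7-fold lower number from compound 2 to compound 4 (0.43 log units; beyond the scatter) and an at least 2.7-fold lower number from compound 1 to compound 4 (0.43 log units; beyond the scatter). This shows that a change of the aryl group on this aromatic nitrogen can bring the number inside the measured range, which the exchanges among the 2-chlorophenyl, 3-chloro-4-methylphenyl and 5-chloro-2-methylphenyl groups could not show, as the steps among those three compounds cannot be read. Within the data shown here, the three new steps give only a lower bound on the size of the change, and compound 4 is the only one with a measured number: the limit of > 50000 nM in this assay, at which 3 of the 4 values shown sit.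

The compounds shown leave open what in the 2,4,6-trichlorophenyl group carries the step, whether the three chlorine atoms as such or their arrangement on the ring, and a 2,4,6-trifluorophenyl or 2,4,6-trimethylphenyl group would bear on that question. They also leave open whether this position tolerates a group of another kind, such as an amine or a carboxylic acid on the phenyl ring.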